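Swapping the aryl on the chain carbon of compound 2

The compounds below may be only part of what the source reports. "The series", "measured", "known", "first", "only" and "open" are said of these compounds alone.

Compound 1 `COc1ccccc1/C=C(\C(=O)c1ccc(Br)cc1)S(=O)(=O)c1ccc(C)cc1` and compound 2 `Cc1ccc(S(=O)(=O)/C(=C/c2ccc(Br)cc2)C(=O)c2ccc(Br)cc2)cc1` share a core and differ only in the ring carried on a double-bonded chain carbon bound to a double-bonded chain carbon. In a functional assay on DU-145 cells (Homo sapiens) for inhibition, read by trypan blue exclusion, with a stated time of 96 h (on this read-out lower numbers stand for stronger inhibition of growth and higher numbers for weaker inhibition of growth), compound 1 gives 1000 nM, while compound 2 gives 10000 nM, the higher of the two numbers and so the weaker grower-inhibitor on this read-out. That gap is a 10-fold higher number from compound 1 to compound 2 (1.00 log units; beyond the scatter).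

Compound 3 `Cc1ccc(S(=O)(=O)/C(=C/c2c[nH]c3ccccc23)C(=O)c2ccc(Br)cc2)cc1` has not yet been measured. It differs from compound 2 at that same place: 1H-indol-3-yl in place of 4-bromophenyl on a double-bonded chain carbon bound to a double-bonded chain carbon. Within the data shown here, the only step that bears on it is the one between compound 1 and compound 2, which shows that exchanging the ring at this position can move the number well beyond the scatter. Nothing measured shows what an indole does there, so the direction rests on one step only. Compound 3 is therefore expected to land at 3000 nM, with a range from 700 nM to 15000 nM, an estimated step of a 3.3-fold lower number from compound 2 to compound 3 (0.52 log units; beyond the scatter) from compound 2.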

Compound 3, concentration for 50% growth inhibition: 10000 nM
Compound 3: the middle estimate sits 3.3-fold (0.52 log units) below what was measured; low and high end bracket the measured number.
By their numbers in this assay, from the lowest: compound 1; then compounds 2 and 3 (each within the scatter of the next).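

In this assay the exchange of 4-bromophenyl for 1H-indol-3-yl gives no change at the digits printed from compound 2 to compound 3 (within the scatter) and so shows that this position does not respond to every change of ring: two groups that differ in size, ring content and hydrogen-bond donor count read alike here. The comparison with the 2-methoxyphenyl group gives a 10-fold higher number from compound 1 to compound 3 (1.00 log units; beyond the scatter) and places compound 1 apart from both of the other compounds, making it the strongest growth inhibitor of the three, while the 4-bromophenyl and 1H-indol-3-yl groups cannot be ranked against each other. No separate measurement accompanies these numbers to explain why the rings behave this way.

Three groups are too few to show which feature of 2-methoxyphenyl goes with the lower number, and a plain phenyl ring or a 4-methoxyphenyl ring at this same chain carbon would help separate the methoxy group itself from its place on the ring. On these data alone, a phenyl ring carrying an amine or a carboxylic acid would further test how far this position tolerates change, and whether any group can reach lower numbers than compound 1 remains open.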